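The compounds below may be only part of what the source reports. "The series", "measured", "known", "first", "only" and "open" are said of these compounds alone.

Working notes on a small series sharing one core. In a functional assay on A549 cells (Homo sapiens) for cytotoxicity, read by MTT assay, with a stated time of 72 h (on this read-out higher numbers stand for weaker inhibition and lower numbers for stronger inhibition), compound 1 (`COc1ccc(NC(=O)CN2CCN(c3nnc(Cc4ccccc4)c4ccccc34)CC2)cc1OC`) gives "not active" (no number reported) and compound 2 (`Cc1ccccc1NC(=O)CN1CCN(c2nnc(Cc3ccccc3)c3ccccc23)CC1`) gives "not active" (no number reported) with no number reported. Compound 3 (`O=C(CN1CCN(c2nnc(Cc3ccccc3)c3ccccc23)CC1)Nc1cc(C(F)(F)F)ccc1Cl`) gives 89000 nM and is the only one of the three with a number, so it cannot yet be placed against a measured neighbour.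

Compound 4 (`O=C(CN1CCN(c2nnc(Cc3ccccc3)c3ccccc23)CC1)Nc1cccc(F)c1`) has not been measured. 3-fluorophenyl in place of 2-chloro-5-(trifluoromethyl)phenyl on an amide-type nitrogen is the whole change from compound 3: 3-fluorophenyl in place of 2-chloro-5-(trifluoromethyl)phenyl on an amide-type nitrogen, with the shared core untouched. Going by the values given here, the series offers no measured step for sizing this replacement.

The expectation therefore rests on two observations: compound 3 sits at 89000 nM and compound 2 reads "not active" (no number reported) in the same test. Compound 4 is expected to stay in this weak range, and a result with no number at all would be no surprise. The estimated change is a 1.3-fold higher number from compound 3 to compound 4 (0.13 log units; within the scatter) and is expected to stay within the usual scatter, leaning weaker if anything. For compound 4 the expected value is 120000 nM with an estimated range from 50000 nM to 300000 nM in this read-out.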

Compound 4, half-maximal inhibitory concentration: 130000 nM
Estimate against measurement, compound 4: 1.1-fold (0.03 log units) below; the measured number falls inside the stated range.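

In this assay this position now has its first measured step, a 1.5-fold higher number from compound 3 to compound 4 (0.16 log units; within the scatter), for 3-fluorophenyl in place of 2-chloro-5-(trifluoromethyl)phenyl on an amide-type nitrogen. The group shrinks from 11 heavy atoms to 7 and loses its chlorine and trifluoromethyl, yet the read-out does not separate the two groups, so a numerical value in this test does not depend on keeping either of those substituents. No measurement of any property of these groups accompanies the result, so the data offer no account of it.

Steps to compound 1 and compound 2 cannot be read, since neither carries a number, and the two measured groups leave open whether any replacement on this nitrogen can move the value clearly away from this weak level. A carboxylic acid or a dimethylamino group on the phenyl ring, a longer chain in place of the ring, or any change to the benzyl group on the shared core remains untested in the compounds shown.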